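The source may hold more compounds than are shown below. What is called first, only, known or untested is meant among the compounds shown, and "the series" means these compounds.

For the measured compounds named here, compound 1 `Cc1ccccc1NC(=O)N1CCC(c2nc(-c3ccc4ccccc4n3)no2)CC1` is one of two compounds measured so far in a functional assay on Shh Light II cells (Mus musculus) for inhibition, read by a luciferase reporter (on this read-out lower numbers stand for stronger inhibition and higher numbers for weaker inhibition), and compound 1 gives 440 nM, the higher of the two numbers. Compound 2 `Cn1c(-c2noc(C3CCN(C(=O)NC4CCCCC4)CC3)n2)nc2ccccc21` gives 89 nM in this assay, a lower number, and the gap between them lies beyond the usual scatter. Compound 3 `O=C(OC1CCCCC1)N1CCC(c2nc(-c3ccc4ccccc4n3)no2)CC1` has not yet been measured. It differs from compound 1 in one place: cyclohexyloxy in place of (2-methylphenyl)amino on a carbonyl carbon. Going by the values given here, no measured pair shows this change, so its effect is unknown. Compound 3 is expected to stay close to compound 1, with the step from compound 1 to compound 3 estimated at a 1.1-fold higher number from compound 1 to compound 3 (0.06 log units; within the scatter), within or near the scatter. Compound 3 is therefore estimated at 500 nM, in the range 150 nM to 1600 nM.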

Compound 3, half-maximal inhibitory concentration: 580 nM
For compound 3 the middle estimate is 1.2-fold (0.06 log units) below the measured one; low and high end bracket the measured number.
By their numbers in this assay, from the lowest: compound 2; then compounds 1 and 3 (each within the scatter of the next).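

In this assay the change to cyclohexyloxy in place of (2-methylphenyl)amino on a carbonyl carbon gives a 1.3-fold higher number from compound 1 to compound 3 (0.12 log units; within the scatter) and so leaves the reading unmoved beyond the scatter. At this position, then, the core of compound 1 keeps its reading although the aromatic ring and the hydrogen-bond donor of the leaving group are both gone. No measurement at hand accounts for this. This single pair cannot separate the ring change from the change of linking atom. As far as these compounds go, whether phenoxy or tert-butoxy would read the same on this core remains open.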